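Fluoro for methyl on two cores: working notes

The source may report more compounds than this note shows. Statements on the series, on what has been measured and on what is new or still open speak of the compounds shown alone.

Measured so far in a functional assay on A549 cells (Homo sapiens) for antiproliferative activity, read by MTT assay, with a stated time of 72 h; a lower number here means a stronger inhibitor, a higher number a weaker inhibitor: compound 1 `COc1ncc(-c2ccc3c(c2)N(c2ccc(C)cc2)C(=O)CO3)cc1NS(=O)(=O)c1ccc(F)cc1` gives 5870 nM. Compound 2 `COc1ncc(-c2ccc3c(c2)N(c2ccc(F)cc2)C(=O)CO3)cc1NS(=O)(=O)c1ccc(F)cc1` gives 6500 nM. Compound 3 `Cc1ccc(N2C(=O)COc3ccc(-c4cccc(NS(=O)(=O)c5ccc(F)cc5)c4)cc32)cc1` is reported only as a limit of the assay, > 40000 nM, not as a number.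

Compound 1 and compound 2 share one core and differ by fluoro in place of methyl on an aromatic carbon; the step is a 1.1-fold higher number from compound 1 to compound 2 (0.04 log units; within the scatter). Compound 3 carries a different core; the difference between the two cores is not broken down here.

Compound 4 `O=C1COc2ccc(-c3cccc(NS(=O)(=O)c4ccc(F)cc4)c3)cc2N1c1ccc(F)cc1` has not yet been measured. It stands to compound 3 as compound 2 stands to compound 1: fluoro in place of methyl on an aromatic carbon, the same change on the same place. Within the data shown here, the only measured instance of this change, a 1.1-fold higher number from compound 1 to compound 2 (0.04 log units; within the scatter), stayed within the scatter, so compound 4 is expected to sit close to compound 3 in this assay, that is, at or beyond the assay limit (the limit of > 40000 nM in this assay, at which 1 of the 3 values shown sits). The expected step is a step that the limit leaves unreadable from compound 3 to compound 4. For compound 4 the estimate in this assay is 45000 nM, between 20000 nM and 100000 nM, with a real chance that only a limit is returned.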

Compound 4, half-maximal inhibitory concentration: > 40000 nM
Compound 4 was reported as a limit; the forecaster's own chance of this, stated with the estimate: 75%; the middle value is on the limit's open side.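

In this assay compound 4 gives > 40000 nM as a limit of the assay, not a number. Among these compounds, compound 3 is also reported only as a limit, so no step from compound 3 to compound 4 can be read: the limit of > 40000 nM in this assay, at which 2 of the 4 values shown sit.

The compounds shown leave open whether fluoro in place of methyl changes activity on the core of compound 3, where neither compound has a number.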